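This account rests on a few compounds, and the source may have more. Where it says the series, first, only, none or still open, it means among the compounds named here.

Measured in a functional assay on M21 cells (Homo sapiens) for antiproliferative activity, read by sulforhodamine B assay, with a stated time of 48 h; on this read-out higher numbers stand for weaker inhibition and lower numbers for stronger inhibition:
Compound 1 `O=C1NCCN1c1ccc(S(=O)(=O)Nc2ccc(I)cc2)cc1`: 260 nM
Compound 2 `O=C1NCCN1c1ccc(S(=O)(=O)Nc2cccc(Br)c2)cc1`: 59 nM
Compound 3 `Cc1cc(C)cc(NS(=O)(=O)c2ccc(N3CCNC3=O)cc2)c1`: 63 nM

Compound 3 stands level with compound 2, as a 1.1-fold higher number from compound 2 to compound 3 (0.03 log units; within the scatter) shows, and well under compound 1, as a 4.1-fold lower number from compound 1 to compound 3 (0.62 log units; beyond the scatter) shows. Compound 4 `O=C1NCCN1c1ccc(S(=O)(=O)Nc2ccc(Br)cc2)cc1` has 4-bromophenyl in place of 3,5-dimethylphenyl on a sulfonamide nitrogen. The nearest measured group is the 4-iodophenyl of compound 1, so a 4.1-fold lower number from compound 1 to compound 3 (0.62 log units; beyond the scatter) bears most directly, read in reverse, and a 4.4-fold lower number from compound 1 to compound 2 (0.64 log units; beyond the scatter) agrees with it. Among the compounds with values here, no measured pair compares 4-bromophenyl with 4-iodophenyl, so only part of that gap is expected to return. The expected change is a modest rise, a 2.4-fold higher number from compound 3 to compound 4 (0.38 log units; beyond the scatter). Compound 4 is estimated at 150 nM, with an expected range of 60 nM to 350 nM.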

Compound 4, half-maximal inhibitory concentration: 130 nM
The estimate for compound 4 lay 1.2-fold (0.06 log units) above the measured number; the range from low to high includes it.
By their numbers in this assay, from the lowest: compounds 2 and 3 (each within the scatter of the next); then compounds 4 and 1 (each within the scatter of the next).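

In this assay, within the data shown here, moving the bromine gives a 2.2-fold higher number from compound 2 to compound 4 (0.34 log units; beyond the scatter) as the only step here that changes where a single halogen sits, so the 3-bromophenyl and 4-bromophenyl are not interchangeable on the sulfonamide nitrogen. The 4-bromophenyl also falls short of the 3,5-dimethylphenyl, with a 2.1-fold higher number from compound 3 to compound 4 (0.31 log units; beyond the scatter) as the step, whereas bromo in place of iodo on an aromatic carbon gives a 2.0-fold lower number from compound 1 to compound 4 (0.30 log units; within the scatter) and so does not separate those two halogens. On these data alone, whether an amine or a carboxylic acid on that phenyl ring would keep the lower numbers of compound 2 and compound 3 stays open. No evidence on hand bears on why these steps arise.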